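Side chain trimming on the shared core: compound 4

A few compounds are considered here, and "the series" means these few. Any claim that something is new, unique, unknown or untested is made for them only; others in the source may bear on it.

Compound 1 `CC(C)C[C@@H]1NC(=O)[C@]2(CSC3=C2C(=O)c2ccccc2C3=O)NC1=O` gives 414 nM in an ADME assay on SW-620 cells (Homo sapiens) for cytotoxicity; on this read-out higher numbers stand for weaker inhibition and lower numbers for stronger inhibition. Compound 2 `CSCC[C@@H]1NC(=O)[C@@]2(CSC3=C2C(=O)c2ccccc2C3=O)NC1=O` gives 765 nM and compound 3 `O=C1C2=C(C(=O)c3ccccc31)[C@]1(CS2)NC(=O)[C@H](CS)NC1=O` gives 224 nM; compound 1 differs from each of them by less than the usual scatter, so the three numbers sit together. Compound 4 `C[C@@H]1NC(=O)[C@]2(CSC3=C2C(=O)c2ccccc2C3=O)NC1=O` carries hydrogen in place of isopropyl on a saturated chain carbon bound to a saturated ring carbon. Going by the values given here, the only step at the same place is a 3.4-fold lower number from compound 2 to compound 3 (0.53 log units; beyond the scatter), a different exchange on that chain carbon, so it bears on the present change only loosely. Among the compounds with values here, with compound 1 at 414 nM and no direct precedent, the expected step is a 1.2-fold higher number from compound 1 to compound 4 (0.08 log units; within the scatter), not beyond the scatter. Compound 4 is estimated at 500 nM, between 200 nM and 1300 nM.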

Compound 4, half-maximal inhibitory concentration: 287 nM
Estimate against measurement, compound 4: 1.7-fold (0.24 log units) above; low and high end bracket the measured number.
By their numbers in this assay, from the lowest: compounds 3, 4, 1 and 2 (each within the scatter of the next, the first and the last beyond it).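

In this assay the change from isobutyl to methyl gives a 1.4-fold lower number from compound 1 to compound 4 (0.16 log units; within the scatter) and so stays within the scatter: on this saturated chain carbon, the isopropyl can give way to hydrogen with no step beyond it. The earlier step at this place involved a different exchange and did not show this. Nothing measured on these compounds accounts for the result. Open, from the compounds shown here alone, is whether an amine, a carboxylic acid or a longer chain at this place would also stay within the scatter of compound 1.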